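The source may report more compounds than this note shows. Statements on the series, on what has been measured and on what is new or still open speak of the compounds shown alone.

Measured compounds:
Compound 1 `CCNc1cc(-c2ccc(NC(=O)Nc3ccc(OC)cc3)cc2C)ccn1` gives 9950 nM as its value
Compound 2 `CCNc1cc(-c2ccc(NC(=O)Nc3ccc(C(F)(F)F)cc3)cc2C)ccn1` gives 6870 nM as its value
Compound 3 `CCNc1cc(-c2ccc(NC(=O)Nc3cccc4ccccc34)cc2C)ccn1` gives 15500 nM as its value

In a functional assay on MCF7 cells (Homo sapiens) for cytotoxicity, read by MTT assay, with a stated time of 24 h (a higher number here means a weaker inhibitor, a lower number a stronger inhibitor), compound 3 gives 15500 nM as its reading. One comparison (a 1.6-fold higher number from compound 1 to compound 3 (0.19 log units; within the scatter)) stays within the scatter, while the other (a 2.3-fold higher number from compound 2 to compound 3 (0.35 log units; beyond the scatter)) goes modestly beyond it.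

Compound 4 `CCNc1cc(-c2ccc(NC(=O)Nc3cccc4ccccc34)cc2C(F)(F)F)ccn1` differs from compound 3 by a single swap trifluoromethyl in place of methyl on an aromatic carbon of trifluoromethyl in place of methyl on an aromatic carbon. For the measured compounds named here, no measured pair makes this swap, so direct evidence is missing. The nearest guide is trifluoromethyl replacing methoxy at a different place in the molecule (a 1.4-fold lower number from compound 1 to compound 2 (0.16 log units; within the scatter)), a step that stayed within the scatter. All three measured steps are small, so no step beyond the scatter is expected in this assay and no firm direction can be claimed.

The estimated change (a 1.4-fold lower number from compound 3 to compound 4 (0.15 log units; within the scatter)) is expected to stay within the scatter. For compound 4 the estimated value is 11000 nM with an expected range from 5000 nM to 25000 nM in this measurement.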

Compound 4, half-maximal inhibitory concentration: 16300 nM
Compound 4: the middle estimate sits 1.5-fold (0.17 log units) below what was measured, within the range that was stated.
By their numbers in this assay, from the lowest: compounds 2, 1, 3 and 4 (each within the scatter of the next, the first and the last beyond it).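

In this assay, trifluoromethyl, with 4 heavy atoms, replaces methyl, with 1, on the aromatic carbon ortho to the 2-(ethylamino)pyridin-4-yl group, and the step is a 1.1-fold higher number from compound 3 to compound 4 (0.02 log units; within the scatter), so this swap leaves the two compounds indistinguishable. For the compounds shown here, the earlier steps changed only the group on the amide-type nitrogen, so this is the first sign that the reading can hold when this other position changes, at least with naphthalen-1-yl in place. No measurement here explains why the reading holds.

On these data alone, whether this holds with 4-methoxyphenyl or 4-(trifluoromethyl)phenyl on that nitrogen remains open, since the swap is seen only once. As far as these compounds go, it is also open whether a very different group at this position, such as an amine or a carboxylic acid, would shift the reading beyond the scatter.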